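A few compounds are considered here, and "the series" means these few. Any claim that something is new, unique, unknown or untested is made for them only; others in the source may bear on it.

Among the measured compounds shown here, compound 2 `CC(C)c1ccccc1OS(=O)(=O)c1ccc(NC(=O)NCCCCl)cc1` is one of two compounds measured in a functional assay on HT-29 cells (Homo sapiens) for antiproliferative activity, read by sulforhodamine B assay, with a stated time of 48 h; on this read-out higher numbers stand for weaker inhibition and lower numbers for stronger inhibition; in it compound 2 gives 6900 nM, the lower of the two numbers. For the measured compounds named here, compound 1 `CC(=O)Nc1ccc(S(=O)(=O)Oc2ccccc2C(C)C)cc1` gives 23000 nM in this assay, and the single measured step, a 3.3-fold lower number from compound 1 to compound 2 (0.52 log units; beyond the scatter), came from putting (3-chloropropyl)amino in place of methyl on a carbonyl carbon. Compound 3 `CC(C)c1ccccc1OS(=O)(=O)c1ccc(NC(=O)NC2CCCC2)cc1` keeps the rest of compound 2 and differs from it by cyclopentyl in place of 3-chloropropyl on an amide-type nitrogen, so 3-chloropropyl leaves and cyclopentyl enters on the amide-type nitrogen. Going by the values given here, no measured step alters this group, so the step from compound 1 to compound 2 bears on it only in showing that changes in this region have moved the number modestly. A step no larger than the usual scatter, in either direction, is therefore expected, a 1.2-fold lower number from compound 2 to compound 3 (0.06 log units; within the scatter). Compound 3 is estimated at 6000 nM, within 2000 nM to 20000 nM.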

Compound 3, half-maximal inhibitory concentration: 7400 nM
Compound 3: middle estimate off by 1.2-fold (0.09 log units), on the low side; low and high end bracket the measured number.
By their numbers in this assay, from the lowest: compounds 2 and 3 (each within the scatter of the next); then compound 1.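

In this assay, cyclopentyl in place of 3-chloropropyl on the amide-type nitrogen gives a 1.1-fold higher number from compound 2 to compound 3 (0.03 log units; within the scatter), so this assay does not tell the chlorine-bearing open chain from the five-membered carbon ring, and for this pair the chlorine is not needed to keep the number at this level. Cyclopentylamino in place of methyl on the carbonyl carbon gives a 3.1-fold lower number from compound 1 to compound 3 (0.49 log units; beyond the scatter), so the earlier gain is not tied to (3-chloropropyl)amino alone. Nothing available explains why these two groups read alike.

Going by these compounds, whether an amine, a carboxylic acid or a longer chain on this nitrogen would read differently remains open. The shared core is the same in all three compounds, which leaves open how much the rest of the structure contributes to the number.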